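Hydroxy to Methyl: Expecting a Fourth Cell-Growth Value

The source may hold more compounds than are shown below. What is called first, only, known or untested is meant among the compounds shown, and "the series" means these compounds.

Compound 1, `Cc1ccc2nc(-c3ccc(NCc4cn(Cc5cc(=O)oc6cc(O)ccc56)nn4)cc3)sc2c1`: 90000 nM
Compound 2, `Cc1ccc2c(Cn3cc(CNc4ccc(-c5nc6ccc(C)cc6s5)cc4)nn3)cc(=O)oc2c1`: >= 100000 nM, a limit of the assay
Compound 3, `O=c1cc(Cn2cc(-n3ccc4cc(I)ccc43)nn2)c2ccc(O)cc2o1`: 34300 nM

All three were tested in a functional assay on SW-620 cells (Homo sapiens) for inhibition, read by MTT assay, with a stated time of 72 h; on this read-out higher numbers stand for weaker inhibition and lower numbers for stronger inhibition. Compound 1 gives 90000 nM. For compound 2 the assay reports >= 100000 nM, which is a limit rather than a number. Compound 3 gives 34300 nM, the lowest of the two numbers. Compound 2 differs from compound 1 by methyl in place of hydroxy on an aromatic carbon, and this change gave an at least 1.1-fold higher number from compound 1 to compound 2 (0.04 log units; that floor lies within the scatter). Because (the limit of >= 100000 nM in this assay, at which 1 of the 3 values shown sits), that step is known only as a floor. The difference between the cores of compound 1 and compound 3 is not broken down here.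

Compound 4, `Cc1ccc2c(Cn3cc(-n4ccc5cc(I)ccc54)nn3)cc(=O)oc2c1`, has not yet been measured; it differs from compound 3 by methyl in place of hydroxy on an aromatic carbon, the same change at the same place. In this assay compound 4 is expected to show a 1.3-fold higher number from compound 3 to compound 4 (0.12 log units; within the scatter), a step estimated to resemble the measured one, an at least 1.1-fold higher number from compound 1 to compound 2 (0.04 log units; that floor lies within the scatter). The estimate for compound 4 is 45000 nM, spanning 20000 nM to 110000 nM.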

Compound 4, half-maximal inhibitory concentration: 70000 nM
Beside the measured number, compound 4's estimate is 1.6-fold (0.19 log units) below it; measured number inside the range.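

In this assay, methyl in place of hydroxy gives a 2.0-fold higher number from compound 3 to compound 4 (0.31 log units; beyond the scatter), a modest weakening of inhibition on the core of compound 3. Set beside the earlier step, this does not show whether the change carries over from one core to the other at the same size: the same change on two cores in this assay, an at least 1.1-fold higher number (0.04 log units; that floor lies within the scatter) from compound 1 to compound 2 and a 2.0-fold higher number (0.31 log units; beyond the scatter) from compound 3 to compound 4; the limit leaves it open whether they differ Compound 2 gives >= 100000 nM, which is a limit of the assay and not a number: the limit of >= 100000 nM in this assay, at which 1 of the 4 values shown sits.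

On these data alone, only hydroxy and methyl appear at this place on the ring, so it stays open how an amine or a carboxylic acid there would read in this assay. The pair is also seen on just two cores, which leaves open whether the change would behave the same way on a third.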